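A few compounds are considered here, and "the series" means these few. Any claim that something is new, unique, unknown or untested is made for them only; others in the source may bear on it.

Compound 1 `COCCO[C@H]1CC[C@H]2CCN(C)[C@H]2C1` gives in an assay on HEK293 cells for displacement of a labelled ligand from Neuronal acetylcholine receptor; alpha4/beta2 (Rattus norvegicus), with a stated time of 4 h (on this read-out lower numbers stand for stronger inhibition and higher numbers for weaker inhibition), a value of 300000 nM. Compound 3 `CN1CC[C@@H]2CC[C@H](O)C[C@@H]21` returns in this assay only the limit > 300000 nM. The change between them is hydrogen in place of 2-methoxyethyl on an oxygen on a saturated carbon; the step of a number no lower from compound 1 to compound 3 (the limit leaves the size open) cannot be sized because compound 3 rests on (the limit of > 300000 nM in this assay, at which 2 of the 3 values shown sit). Compound 2 `COCCO[C@H]1CC=C2CCN(C)[C@H]2C1` carries the same 2-methoxyethoxy group, but the difference between its core and that of compound 1 is not broken down here. In this assay compound 2 shows only the limit > 300000 nM. Compound 4 `CN1CCC2=CC[C@H](O)C[C@@H]21` is still to be measured in this assay; it differs from compound 2 by hydrogen in place of 2-methoxyethyl on an oxygen on a saturated carbon, the same change as from compound 1 to compound 3. The expected step that the limit leaves unreadable from compound 2 to compound 4 rests on the unreadable step a number no lower from compound 1 to compound 3 (the limit leaves the size open) and on compound 2 already sitting at the limit of > 300000 nM in this assay, at which 2 of the 3 values shown sit. For compound 4 the estimate is 400000 nM.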

Compound 4, inhibition constant: 300000 nM
For compound 4 the middle estimate is 1.3-fold (0.12 log units) above the measured one; the measured number falls inside the stated range.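

In this assay the new step reads a number no higher from compound 2 to compound 4 (the limit leaves the size open) and cannot be given a size. Neither step from 2-methoxyethoxy to hydroxy can be read in size in this assay, so the two cores cannot be compared for this change: the same change on two cores in this assay, a number no lower (the limit leaves the size open) from compound 1 to compound 3 and a number no higher (the limit leaves the size open) from compound 2 to compound 4; the limit leaves it open whether they differ. For the compounds shown here, the pairs show only that the hydroxy compound on one core and the 2-methoxyethoxy compound on the other rest on a limit; they do not show whether the change carries over unaltered or differs between the cores. Each pair has one member on the same limit: the limit of > 300000 nM in this assay, at which 2 of the 4 values shown sit.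

Still open, from the compounds shown here alone, is how this change behaves on a compound with a value well clear of that limit. Also open, going by these compounds, is whether an amine or a longer chain on that oxygen, in place of 2-methoxyethyl, gives a readable value in this assay.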